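The compounds below may be only part of what the source reports. "The series", "measured", "known", "first", "only" and "open" are said of these compounds alone.

Measured compounds in an assay on membranes from CHO cells for displacement of a labelled ligand from adenosine receptor A1 (Homo sapiens), read by scintillation counting, with a stated time of 60 min, tested at 1 uM; on this read-out higher numbers stand for more inhibition at the one concentration tested (going by the name of the read-out) and lower numbers for less inhibition:
compound 1, `CC1=C(C(=O)OC2CCCCC2)C(c2ccco2)NC(=O)N1`, gives 1%
compound 2, `CC1=C(C(=O)OCC2CC2)C(c2ccco2)NC(=O)N1`, gives 29%
compound 3, `CC1=C(C(=O)OC2CCCCC2)C(c2cccs2)NC(=O)N1`, gives 7%

Compound 1 and compound 2 differ in one place, (cyclopropylmethyl in place of cyclohexyl on an oxygen next to a carbonyl group); the step is a number 28 percentage points higher from compound 1 to compound 2 (beyond the scatter).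

Compound 3 carries a different core from compound 1, the difference being (thiophen-2-yl in place of furan-2-yl on a saturated ring carbon); the step is a number 6 percentage points higher from compound 1 to compound 3 (within the scatter), so the two cores read alike here.

Compound 4, `CC1=C(C(=O)OCC2CC2)C(c2cccs2)NC(=O)N1`, has not been measured in this assay. It stands to compound 3 as compound 2 stands to compound 1: cyclopropylmethyl in place of cyclohexyl on an oxygen next to a carbonyl group. The place is the same word for word in both pairs, so this is the same change, occurring twice among the compounds shown.

Among the compounds with values here, the expectation for compound 4 rests on the one earlier step, a number 28 percentage points higher from compound 1 to compound 2 (beyond the scatter), carried over to the core of compound 3; the step expected is a number 28 percentage points higher from compound 3 to compound 4 (beyond the scatter), beside the earlier one. Within the data shown here, with only a single prior instance, the range is kept wide. Compound 4 is thus estimated at 35%, between 15% and 55%.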

Compound 4, a percentage reported as inhibition, at one concentration (the size of the read-out at that concentration, not a potency): 23%
The estimate for compound 4 lay 12 percentage points above the measured number; the measured number falls inside the stated range.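

In this assay, cyclopropylmethyl in place of cyclohexyl on an oxygen next to a carbonyl group again gives a step beyond the scatter on the core of compound 3, a number 16 percentage points higher from compound 3 to compound 4 (beyond the scatter), and the two instances of this change agree: the same change on two cores in this assay, a number 28 percentage points higher (beyond the scatter) from compound 1 to compound 2 and a number 16 percentage points higher (beyond the scatter) from compound 3 to compound 4, 12 percentage points apart, within the scatter of two such steps

Thiophen-2-yl in place of furan-2-yl on a saturated ring carbon also stays within the scatter when cyclopropylmethyl is present, a number 6 percentage points lower from compound 2 to compound 4 (within the scatter), so this swap reads alike in both settings: the same change on two cores in this assay, a number 6 percentage points higher (within the scatter) from compound 1 to compound 3 and a number 6 percentage points lower (within the scatter) from compound 2 to compound 4, 12 percentage points apart, within the scatter of two such steps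

The change therefore carries across the two cores shown, but two pairs read at one concentration give no potencies and do not show that the step would hold on any other core.

Open, going by these compounds, is how a longer chain, such as n-hexyl, or a chain ending in an amine would read on that oxygen. Also open, on these data alone, is how phenyl would read on the saturated ring carbon, and whether the cyclopropylmethyl step would persist there.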